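This account rests on a few compounds, and the source may have more. Where it says the series, first, only, none or still open, it means among the compounds named here.

Compound 1, `COc1cc(-c2nnc3n2NC(c2ccco2)C(C(=O)c2cccs2)S3)cc(OC)c1OC`: in a functional assay on MCF7 cells (Homo sapiens) for cytotoxicity, read by MTT assay, with a stated time of 48 h (a higher number here means a weaker inhibitor, a lower number a stronger inhibitor), compound 1 gives > 100000 nM, which is a limit of the assay and not a number.
Compound 2, `COc1cc(-c2nnc3n2NC(c2ccco2)C(C(=O)c2cccc4ccccc24)S3)cc(OC)c1OC`: in this assay compound 2 gives > 100000 nM, likewise a limit of the assay.
Compound 3, `COc1cc(-c2nnc3n2NC(c2ccco2)C(C(=O)c2ccc(O)cc2)S3)cc(OC)c1OC`: in this assay compound 3 gives 88900 nM.

Among the compounds with values here, compound 3 thus holds the only number among the three compounds measured; the other two sit at the limit of > 100000 nM in this assay, at which 2 of the 3 values shown sit. The steps towards compound 3 are floors only: an at least 1.1-fold lower number from compound 1 to compound 3 (0.05 log units; that floor lies within the scatter) and an at least 1.1-fold lower number from compound 2 to compound 3 (0.05 log units; that floor lies within the scatter). The step that the two limits leave unreadable from compound 1 to compound 2 cannot be read at all. Compound 4, `COc1cc(-c2nnc3n2NC(c2ccco2)C(C(=O)c2ccc(C(F)(F)F)cc2)S3)cc(OC)c1OC`, differs from compound 3 by trifluoromethyl in place of hydroxy on an aromatic carbon. Within the data shown here, no measured step covers this exact change; the measured steps bear on it only in that two groups on the carbonyl carbon give limits and one gives a number. Compound 4 is therefore expected to remain in the same weak region, with an expected step of a 1.3-fold higher number from compound 3 to compound 4 (0.13 log units; within the scatter) of no certain direction, and it would not be surprising if the expected number for compound 4 were beyond what the assay can resolve. Compound 4 is estimated at 120000 nM in this assay, between 40000 nM and 400000 nM.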

Compound 4, half-maximal inhibitory concentration: 33600 nM
For compound 4 the middle estimate is 3.6-fold (0.55 log units) above the measured one; the measured number lies below the stated range.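

In this assay, within the data shown here, trifluoromethyl in place of hydroxy on this aromatic carbon gives a 2.6-fold lower number from compound 3 to compound 4 (0.42 log units; beyond the scatter), the first step that can be read as a number and not merely as a floor. Hydroxy is therefore not required for a readable value, and compound 3 no longer stands alone in having one. The 4-(trifluoromethyl)phenyl group also gives an at least 2.9-fold lower number from compound 2 to compound 4 (0.47 log units; beyond the scatter) and an at least 2.9-fold lower number from compound 1 to compound 4 (0.47 log units; beyond the scatter), the first steps from those compounds to clear the scatter, though both remain floors set by assay limits: the limit of > 100000 nM in this assay, at which 2 of the 4 values shown sit.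

From the compounds shown here alone, whether an amine, a chlorine atom or a carboxylic acid on this aromatic carbon would track compound 3 or compound 4 remains open. Also open, going by these compounds, is whether the step from hydroxy to trifluoromethyl would hold if the rest of the core were changed.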